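Swapping cyano for fluoro on a thiourea series

The compounds below may be only part of what the source reports. "The series", "measured", "known", "first", "only" and "open" are said of these compounds alone.

Measured in an ADME assay on MDBK cells (Bos taurus) for cytotoxicity, read by MTT assay, with a stated time of 96 h; on this read-out lower numbers stand for higher toxicity in this test and higher numbers for lower toxicity in this test:
Compound 1, `CC[C@H]1CC[C@H](c2ccc(NC(=S)Nc3cccc(C(F)(F)F)c3)cc2)CC1`: 9000 nM
Compound 2, `FC(F)(F)c1cccc(NC(=S)Nc2ccc(Cl)cc2)c1`: 17000 nM
Compound 3, `N#Cc1ccc(NC(=S)Nc2cccc(C(F)(F)F)c2)cc1`: 10000 nM

Compound 3 gives 10000 nM, which sets it apart from neither of the other two compounds: the steps that reach it are a 1.1-fold higher number from compound 1 to compound 3 (0.05 log units; within the scatter) and a 1.7-fold lower number from compound 2 to compound 3 (0.23 log units; within the scatter). Compound 4, `Fc1ccc(NC(=S)Nc2cccc(C(F)(F)F)c2)cc1`, has not yet been measured. It differs from compound 3 in one place, (fluoro in place of cyano on an aromatic carbon), with fluoro in place of cyano on an aromatic carbon, para to a large group. Going by the values given here, no measured step makes this exact exchange, so the evidence is indirect. The same place has been varied in the other compounds, and even the exchange of 4-ethylcyclohexyl for chloro gave only a 1.9-fold higher number from compound 1 to compound 2 (0.28 log units; within the scatter). On these three compounds alone, no change beyond the scatter is expected in this assay. The expected step is a 1.2-fold higher number from compound 3 to compound 4 (0.08 log units; within the scatter). Compound 4 is estimated at 12000 nM, with an expected range from 6000 nM to 25000 nM.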

Compound 4, half-maximal cytotoxic concentration: 41000 nM
For compound 4 the middle estimate is 3.4-fold (0.53 log units) below the measured one; the measured number lies above the stated range.
By their numbers in this assay, from the lowest: compounds 1, 3 and 2 (each within the scatter of the next); then compound 4.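

In this assay this position proves able to move the number after all, with a 4.1-fold higher number from compound 3 to compound 4 (0.61 log units; beyond the scatter) for fluoro against cyano, a 2.4-fold higher number from compound 2 to compound 4 (0.38 log units; beyond the scatter) for fluoro against chloro and a 4.6-fold higher number from compound 1 to compound 4 (0.66 log units; beyond the scatter) for fluoro against 4-ethylcyclohexyl. The earlier groups had stayed within the scatter of one another, so compound 4 is the only one of the four that separates from the rest, towards lower toxicity in this test. Nothing available accounts for why fluoro alone does this.

As far as these compounds go, whether a methoxy group, an amine or a bromine at this place would fall with compound 4 or with the other three remains open. From the compounds shown here alone, it is also open whether the fluoro exchange would keep its size if the trifluoromethyl group elsewhere in the shared core were replaced by a methyl group.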